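Methyl in place of fluoro: compound 1 to compound 4

The source may report more compounds than this note shows. Statements on the series, on what has been measured and on what is new or still open speak of the compounds shown alone.

Of the compounds shown here, three have been measured so far in a functional assay (plasma) for inhibition, with Homo sapiens as the target; on this read-out higher numbers stand for weaker inhibition and lower numbers for stronger inhibition. Compound 1 `O=C(O)CCC/C=C\C[C@H]1C(=O)CC[C@@H]1NS(=O)(=O)c1ccc(F)cc1` gives 500 nM, the second highest of the three numbers. Compound 2 `O=C(O)CCC/C=C\C[C@@H]1[C@@H](NS(=O)(=O)c2ccc(Cl)cc2)CC[C@@H]1O` gives 190 nM, and compound 3 `O=C(O)CCC/C=C\C[C@@H]1[C@H](O)CC[C@H]1NS(=O)(=O)c1ccc(Cl)cc1` gives 2200 nM. Compound 1 lies between those two, and its distance to each is beyond the scatter. Within the data shown here, the only step between compounds that differ in a single place is a 12-fold higher number from compound 2 to compound 3 (1.06 log units; beyond the scatter); that step rests on (the fact that compounds 2 and 3 differ only in the configuration as drawn), a change of configuration alone and not of any group.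

Compound 4 `Cc1ccc(S(=O)(=O)N[C@H]2CCC(=O)[C@@H]2C/C=C\CCCC(=O)O)cc1` has not yet been measured. It differs from compound 1 in one place: methyl in place of fluoro on an aromatic carbon, which read a bond further out is 4-fluorophenyl to 4-methylphenyl. Among the measured compounds shown here, no measured step bears on this change. For the measured compounds named here, the one measured step concerns configuration only, and none of the measured compounds carries a methyl on that ring, so the numbers give no guide to the direction or size of the effect. The expectation therefore rests on compound 1 alone: the expected step is no change at the digits printed from compound 1 to compound 4 (within the scatter), which is not expected to go beyond the scatter in either direction. Compound 4 is estimated at 500 nM, with a range from 200 nM to 1300 nM.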

Compound 4, half-maximal inhibitory concentration: 670 nM
The estimate for compound 4 lay 1.3-fold (0.13 log units) below the measured number, and the stated range covers the measured number.
By their numbers in this assay, from the lowest: compound 2; then compounds 1 and 4 (each within the scatter of the next); then compound 3.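

On the aromatic carbon para to a large group, methyl in place of fluoro gives a 1.3-fold higher number from compound 1 to compound 4 (0.13 log units; within the scatter) in this assay, so compound 1 and compound 4 cannot be told apart on this read-out. This is the first step shown that exchanges a group, as the only earlier step, a 12-fold higher number from compound 2 to compound 3 (1.06 log units; beyond the scatter), involves configuration alone, and it shows that on the core of compound 1 the 4-methylphenyl group reads like the 4-fluorophenyl group, so a fluoro at this place is not required for a number of this size. No measured property of either group is available to bear on this result.

The compounds shown leave open how a methoxy group, a trifluoromethyl group, an amine or a plain hydrogen at this same place would read, and so how far this position tolerates other groups. They also leave open whether methyl would read the same on the cores of compound 2 and compound 3, which carry a hydroxyl group and a chloro group in place of the ketone and the fluoro of compound 1.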